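The source may hold more compounds than are shown below. What is called first, only, known or untested is meant among the compounds shown, and "the series" means these compounds.

Compound 1 `COc1ccc(-c2ccc([C@@H](c3ccccc3)[C@@](O)(CCN(C)C)c3cccc4ccccc34)c(OC)n2)cc1`: > 64 ug/mL
Compound 2 `COc1nc(-c2ccc(OC(F)(F)F)cc2)ccc1[C@@H](c1ccccc1)[C@@](O)(CCN(C)C)c1cccc2ccccc12`: > 64 ug/mL

Both measured compounds share one core and differ only at the methoxy group on the distal benzene ring. In a toxicity assay on HeLa cells (Homo sapiens) for cytotoxicity (a higher number here means that more compound is tolerated, a lower number that less compound is tolerated), compound 1 is reported only as a limit, > 64 ug/mL. In this assay compound 2 is likewise reported only as a limit, > 64 ug/mL. The change between them, trifluoromethyl in place of methyl on an oxygen on an aromatic ring, gives a step that the two limits leave unreadable from compound 1 to compound 2, so the two values cannot be compared beyond saying that both sit at the limit of > 64 ug/mL in this assay, at which 2 of the 2 values shown sit.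

Compound 3 `COc1nc(-c2ccc(C#N)cc2)ccc1[C@@H](c1ccccc1)[C@@](O)(CCN(C)C)c1cccc2ccccc12` takes the next step: cyano in place of trifluoromethoxy on an aromatic carbon. Within the data shown here, no measured step reads as a number, so no size can be taken from the earlier pair; compound 2 itself stands only at a limit. The expectation for this assay is therefore a step that the limit leaves unreadable from compound 2 to compound 3, that is, none beyond the scatter. Compound 3 is accordingly estimated at 70 ug/mL, with a range of 30 ug/mL to 160 ug/mL, and most likely again reported only as a limit.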

Compound 3, half-maximal cytotoxic concentration: > 64 ug/mL
Compound 3 ended at the assay's limit (the forecaster's own chance of this, stated with the estimate: 75%); the middle value does not contradict the limit.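

Compound 1, compound 2 and compound 3 are each reported only as a limit in this assay, so no step among them can be read: the limit of > 64 ug/mL in this assay, at which 3 of the 3 values shown sit.

The compounds shown leave open whether the methoxy, trifluoromethoxy and cyano groups differ at all in this assay, since any difference would lie beyond that limit.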